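Nitrofuran to nitrothiophene: a cytotoxicity step

The compounds below may be only part of what the source reports. "The series", "measured", "known", "first", "only" and "open" are said of these compounds alone.

Measured compounds:
Compound 1 `O=C(Nc1ccc(S(=O)(=O)N2CCC3(CCCCC3)CC2)cc1)c1ccc([N+](=O)[O-])o1`: in an ADME assay on IMR-90 cells (Homo sapiens) for cytotoxicity, read by CellTiter-Blue, with a stated time of 46 h (a lower number here means that less compound is needed, a higher number that more compound is needed for the effect), compound 1 gives > 25000 nM, which is a limit of the assay and not a number.
Compound 2 `O=C(Nc1ccc(S(=O)(=O)N2CCC(O)CC2)cc1)c1ccc([N+](=O)[O-])o1`: in this assay compound 2 gives > 25000 nM, again a limit and not a number.

Going by the values given here, compound 1 thus stands only at a limit of this assay, and the sole other value shown sits at that same limit (the limit of > 25000 nM in this assay, at which 2 of the 2 values shown sit). Among the compounds with values here, no step between measured compounds with a single point of difference is available. Compound 3 `O=C(Nc1ccc(S(=O)(=O)N2CCC3(CCCCC3)CC2)cc1)c1ccc([N+](=O)[O-])s1` differs from compound 1 in one place: 5-nitrothiophen-2-yl in place of 5-nitrofuran-2-yl on a carbonyl carbon. With both shown values resting at a limit, no direction can be read for this change, and no step beyond the usual scatter is expected. The half-maximal effective concentration of compound 3 in this assay is estimated at 30000 nM, between 10000 nM and 100000 nM, so the expected step that the limit leaves unreadable from compound 1 to compound 3 is none beyond the scatter.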

Compound 3, half-maximal effective concentration: > 25000 nM
Compound 3 gave a limit, no number (the forecaster's own chance of this, stated with the estimate: 80%); the middle value does not contradict the limit.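

No new step can be read between compound 1 and compound 3, as each gives only a limit and not a number: the limit of > 25000 nM in this assay, at which 3 of the 3 values shown sit. The compounds shown leave open whether 5-nitrothiophen-2-yl and 5-nitrofuran-2-yl differ at all in this assay.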